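A few compounds are considered here, and "the series" means these few. Any claim that something is new, unique, unknown or untested is made for them only; others in the source may bear on it.

Compound 1 `CNC(=O)CN1CCC(c2cc3c(-c4ccc(=O)n(C(C)C)c4)ccnc3[nH]2)CC1`: 0.7 h
Compound 2 `COc1cc(F)ccc1-c1ccnc2[nH]c(C3CCN(CC(=O)N(C)C)CC3)cc12`: 1 h

Both compounds were measured in an ADME assay (Rattus norvegicus, strain Han-wistar) for metabolic stability, at a dose of 1.5 umol/kg by the intravenous route; on this read-out higher numbers stand for a longer-lived compound and lower numbers for a shorter-lived compound. Compound 2 stands at 1 h and compound 1 at 0.7 h; these two values lie within the scatter of each other, so they cannot be ranked. Compound 3 `CC(C)n1nc(-c2ccnc3[nH]c(C4CCN(CC(=O)N(C)C)CC4)cc23)ccc1=O` departs from compound 2 on an aromatic carbon, opposite the ring nitrogen: a group of 10 heavy atoms (7 carbon, 2 nitrogen, 1 oxygen; one six-membered aromatic ring with 2 hetero atoms) in place of a group of 9 heavy atoms (7 carbon, 1 oxygen, 1 fluorine; one six-membered aromatic ring of carbon only), on an aromatic carbon. Among the measured compounds shown here, no measured pair isolates this change. The nearest guide is compound 1, whose group at that place resembles the entering one and which gives 0.7 h. In this assay no change beyond the scatter is expected, and the estimated step is a 1.3-fold lower number from compound 2 to compound 3 (0.10 log units; within the scatter). The expected value for compound 3 is 0.8 h, with an estimated range of 0.4 h to 1.6 h.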

Compound 3, half-life: 1 h
The estimate for compound 3 lay 1.3-fold (0.10 log units) below the measured number; low and high end bracket the measured number.
By their numbers in this assay, from the lowest: compounds 1, 2 and 3 (each within the scatter of the next).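

In this assay, among the compounds shown here, the pair gives the first direct reading of a single exchange on the aromatic carbon opposite the ring nitrogen: replacing 4-fluoro-2-methoxyphenyl with a six-membered aromatic ring with 2 hetero atoms gives no change at the digits printed from compound 2 to compound 3 (within the scatter). At this place, therefore, the ring of carbon only can give way to this group, which has a double bond outside the aromatic ring, with no measurable effect on half-life, at least on this core and with this side chain. Nothing measured here speaks to the reason for this outcome. Going by these compounds, whether an amine or a carboxylic acid on this aromatic carbon would shift the half-life beyond the scatter remains open. So does whether the same exchange would give the same result elsewhere in the series, since it rests on this one pair.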